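The source may report more compounds than this note shows. Statements on the series, on what has been measured and on what is new or still open speak of the compounds shown alone.

Of the compounds shown here, three of one shared core have been measured so far, and compound 3 `CCc1ccc2c(c1)N(C1=CCCC1=O)CC(C)(C)S2` is the point of departure. In a functional assay on aorta (Rattus norvegicus, strain Wistar) (a lower number here means a smaller maximal response, a higher number a larger maximal response), compound 3 reaches 97%. Compound 2 `CC(=O)Nc1ccc2c(c1)N(C1=CCCC1=O)CC(C)(C)S2` reaches 97% in this assay, and compound 3 stands level with it at the digits shown, so the two share the highest numbers of the set. Compound 1 `Cc1ccc2c(c1)N(C1=CCCC1=O)CC(C)(C)S2` reaches 89% in this assay; the step of a number 8 percentage points higher from compound 1 to compound 3 (within the scatter) is its distance to compound 3.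

The next compound to be tested is compound 4 `CC1(C)CN(C2=CCCC2=O)c2cc(C(F)(F)F)ccc2S1`. It differs from compound 3 in one place: trifluoromethyl in place of ethyl on an aromatic carbon.

Three measured steps exchange a group on the same aromatic carbon of the core and so bear on this change. The step of no change at the digits printed from compound 2 to compound 3 (within the scatter) swapped ethyl for acetamido, the step of a number 8 percentage points higher from compound 1 to compound 2 (within the scatter) swapped acetamido for methyl, and the step of a number 8 percentage points higher from compound 1 to compound 3 (within the scatter) grew methyl to ethyl. Each of them stayed inside the usual scatter, so exchanges at this carbon have not moved the maximal response so far. The trifluoromethyl group has not been tested here, but nothing in the three steps argues for a change beyond the scatter. The expected step is therefore a number 3 percentage points lower from compound 3 to compound 4 (within the scatter). Compound 4 is estimated at 94%, with a range from 80% to 104%.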

Compound 4, largest response reached (Emax), in percent of the reference or control that the assay uses: 92%
Compound 4: the middle estimate sits 2 percentage points above what was measured; the range from low to high includes it.
By their numbers in this assay, from the lowest: compounds 1, 4, 2 and 3 (each within the scatter of the next).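

Trifluoromethyl is the first group in this series to bring fluorine to this aromatic carbon, yet in this assay all three of its comparisons stay within the scatter: (a number 5 percentage points lower from compound 3 to compound 4 (within the scatter)), (a number 5 percentage points lower from compound 2 to compound 4 (within the scatter)) and (a number 3 percentage points higher from compound 1 to compound 4 (within the scatter)). Within the data shown here, the largest response therefore remains unchanged within the scatter across four different groups at this carbon (methyl, ethyl, acetamido and trifluoromethyl), no compound among the four goes against this, and no ranking of these groups can be drawn from the numbers. Nothing available here explains why the exchange leaves the response within the scatter.

Going by these compounds, it remains open whether an amine, a carboxylic acid or a longer chain such as butyl at this carbon would move the largest response beyond the scatter, or whether a plain hydrogen there would do so. On these data alone, all four compounds also share the rest of the core, so the effect of replacing its ring ketone or its two methyl groups is unknown, as is how much compound each one needs to reach its largest response.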